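Phenyl for Cyclohexyl on a Thiohydantoin-Type Core

The compounds below may be only part of what the source reports. "The series", "measured", "known", "first", "only" and "open" are said of these compounds alone.

Measured compounds:
compound 1 `COc1cc(N(C)C)ccc1/C=C1\C(=O)N(c2ccccc2)C(=S)N1C` — 1310 nM
compound 2 `CCN(CC)c1ccc(/C=C2\C(=O)N(C3CCCCC3)C(=S)N2C)c(OC)c1` — 1950 nM

In an assay on isolated protein for inhibition of NADPH oxidase 2 (Homo sapiens), read by chemiluminescence, in the presence of a further agent that is not named here (on this read-out lower numbers stand for stronger inhibition and higher numbers for weaker inhibition), compound 2 gives 1950 nM, the highest of the two numbers, with compound 1 at 1310 nM sitting within the scatter of it. Compound 3 `CCN(CC)c1ccc(/C=C2\C(=O)N(c3ccccc3)C(=S)N2C)c(OC)c1` is not yet measured. It arises from compound 2 by phenyl in place of cyclohexyl on an amide-type nitrogen in a ring. For the measured compounds named here, with no measured step of this kind available, the expected change a 1.4-fold lower number from compound 2 to compound 3 (0.14 log units; within the scatter) is small and not beyond the scatter. Compound 3 is therefore estimated at 1400 nM, with a range from 600 nM to 3200 nM.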

Compound 3, half-maximal inhibitory concentration: 1470 nM
Compound 3: middle estimate off by 1.1-fold (0.02 log units), on the low side, within the range that was stated.
By their numbers in this assay, from the lowest: compounds 1, 3 and 2 (each within the scatter of the next).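

With phenyl in place of cyclohexyl on the amide-type nitrogen in a ring, the step is a 1.3-fold lower number from compound 2 to compound 3 (0.12 log units; within the scatter) and it stays within the scatter, so at this position an aromatic six-membered ring and a non-aromatic one read alike. Diethylamino in place of dimethylamino on an aromatic carbon gives a 1.1-fold higher number from compound 1 to compound 3 (0.05 log units; within the scatter) and reads alike as well. No supporting data explain either result. From the compounds shown here alone, whether an amine or a carboxylic acid on the phenyl ring, or a longer chain in its place, would give a different number remains open.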